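Acyclic uracil series: bromoethenyl replacing nitro at the ring

This account rests on a few compounds, and the source may have more. Where it says the series, first, only, none or still open, it means among the compounds named here.

Compound 1 `O=c1ccn(COCCO)c(=O)[nH]1` is the unsubstituted parent of the series. In a functional assay (Oryctolagus cuniculus) for inhibition (on this read-out lower numbers stand for stronger inhibition and higher numbers for weaker inhibition), compound 1 gives > 400 ug/mL, a limit of the assay. Compound 2 `Cc1cn(COCCO)c(=O)[nH]c1=O` gives in this assay > 400 ug/mL, again a limit. Compound 3 `O=c1[nH]c(=O)n(COCCO)cc1[N+](=O)[O-]` gives in this assay > 400 ug/mL, also only a limit; it therefore stands at the limit of > 400 ug/mL in this assay, at which 3 of the 3 values shown sit. The steps a step that the two limits leave unreadable from compound 1 to compound 2, a step that the two limits leave unreadable from compound 1 to compound 3 and a step that the two limits leave unreadable from compound 2 to compound 3 cannot be sized from these limits. Compound 4 `O=c1[nH]c(=O)n(COCCO)cc1/C=C/Br` differs from compound 3 by 2-bromoethenyl in place of nitro on an aromatic carbon. Among the measured compounds shown here, no measured step bears on this change; no direction can be read. Compound 4 is estimated in this assay at 300 ug/mL, between 80 ug/mL and 900 ug/mL. The expected step is an at least 1.3-fold lower number from compound 3 to compound 4 (0.12 log units; that floor lies within the scatter).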

Compound 4, concentration for 50% inhibition: > 200 ug/mL
Compound 4 ended at the assay's limit (the forecaster's own chance of this, stated with the estimate: 60%); the middle value does not contradict the limit.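

Among the compounds shown here, compound 4, like compound 1, compound 2 and compound 3, gives only a limit, so no step to compound 4 can be read. The compounds shown leave open whether hydrogen, methyl, nitro and 2-bromoethenyl differ in inhibition at all.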